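Swapping the 1,3-Oxazol-2-yl Group for 3-Cyanophenyl

The source may report more compounds than this note shows. Statements on the series, on what has been measured and on what is new or still open speak of the compounds shown alone.

Compound 1 `Nc1nc(-c2ncco2)nc2sc(CN3CC=CC3)cc12` and compound 2 `Nc1nc(-c2ncco2)nc2sc(CN3CC=CCC3)cc12` share one core and differ only in the ring on the saturated chain carbon. Among the compounds with values here, in an assay on CHO-K1 cells for antagonist activity at adenosine receptor A1 (Homo sapiens), read by a beta-galactosidase reporter, with stated times of 15 min and 6 h (on this read-out lower numbers stand for stronger inhibition and higher numbers for weaker inhibition), compound 1 gives 3890 nM, and compound 2 gives 2960 nM; the step of a 1.3-fold lower number from compound 1 to compound 2 (0.12 log units; within the scatter) leaves the two within the scatter of each other, so compound 2 stands level with compound 1 on the two numbers known so far. Compound 3 `N#Cc1cccc(-c2nc(N)c3cc(CN4CC=CCC4)sc3n2)c1` carries 3-cyanophenyl in place of 1,3-oxazol-2-yl on an aromatic carbon. Within the data shown here, no measured step touches this aromatic carbon; the single known step concerns the ring on the saturated chain carbon and says nothing about exchanging the 1,3-oxazol-2-yl group for the 3-cyanophenyl group, so the expectation for compound 3 rests on the starting value alone. Compound 3 is therefore expected near 2000 nM, in a wide range from 300 nM to 13000 nM, a step of a 1.5-fold lower number from compound 2 to compound 3 (0.17 log units; within the scatter) that is an estimate only.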

Compound 3, inhibition constant: 210 nM
For compound 3 the middle estimate is 9.5-fold (0.98 log units) above the measured one, and the stated range ends above it.
By their numbers in this assay, from the lowest: compound 3; then compounds 2 and 1 (each within the scatter of the next).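

In this assay, the aromatic carbon between two ring nitrogen atoms proves far more responsive than the saturated chain carbon: exchanging 1,3-oxazol-2-yl for 3-cyanophenyl gives a 14-fold lower number from compound 2 to compound 3 (1.15 log units; beyond the scatter). Within the data shown here, the earlier ring change, a 1.3-fold lower number from compound 1 to compound 2 (0.12 log units; within the scatter), gave no sign of this, so this is the first change to move the number beyond the scatter. Here, the lower number comes with the larger 3-cyanophenyl group, which has one hydrogen-bond acceptor where 1,3-oxazol-2-yl has two. No measurement bears on why the number falls.

The compounds shown do not separate the contribution of the benzene ring from that of the nitrile, which a plain phenyl group at this carbon would address. They also leave open whether 3-cyanophenyl would give a similar step alongside the five-membered ring of compound 1.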